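A few compounds are considered here, and "the series" means these few. Any claim that something is new, unique, unknown or untested is made for them only; others in the source may bear on it.

Of the compounds shown here, three built on one shared core have been measured in an assay on isolated protein for binding affinity to melanin-concentrating hormone receptor 1 (Homo sapiens); on this read-out lower numbers stand for stronger inhibition and higher numbers for weaker inhibition. Compound 1 `CN1CCN(CCCN(c2nc3cc(Cl)c(Cl)cc3[nH]2)[C@@H]2CC[C@]3(c4cccc(C#N)c4)C[C@@H]3C2)CC1` gives 2.2 nM, compound 2 `CN1CCN(CCCN(c2nc3cc(F)c(Cl)cc3[nH]2)[C@@H]2CC[C@]3(c4cccc(C#N)c4)C[C@@H]3C2)CC1` gives 6.2 nM, and compound 3 `N#Cc1cccc([C@]23CC[C@@H](N(CN4CCCCC4)c4nc5cc(Cl)c(Cl)cc5[nH]4)C[C@H]2C3)c1` gives 2.5 nM. Compound 2 therefore stands highest of the three, with compound 3 nearest and compound 1 furthest; the step of a 2.8-fold higher number from compound 1 to compound 2 (0.45 log units; beyond the scatter) came with fluoro in place of chloro on an aromatic carbon. Compound 4 `CS(=O)(=O)N1CCC(CN(c2nc3cc(F)c(Cl)cc3[nH]2)[C@@H]2CC[C@]3(c4cccc(C#N)c4)C[C@@H]3C2)CC1` differs from compound 2 in one place: 1-(methylsulfonyl)piperidin-4-yl in place of 2-(4-methylpiperazin-1-yl)ethyl on a saturated chain carbon bound to a nitrogen on an aromatic ring. Among the compounds with values here, one measured step touches the same place: a 1.1-fold higher number from compound 1 to compound 3 (0.06 log units; within the scatter), where piperidin-1-yl replaced 2-(4-methylpiperazin-1-yl)ethyl. A change at this chain carbon thus left the number essentially where it was. On that basis only a small step is expected in this assay, a 1.0-fold lower number from compound 2 to compound 4 (0.01 log units; within the scatter), in no sure direction. Compound 4 is therefore estimated at 6 nM, within a range from 2 nM to 18 nM.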

Compound 4, inhibition constant: 6.7 nM
The estimate for compound 4 lay 1.1-fold (0.05 log units) below the measured number; low and high end bracket the measured number.
By their numbers in this assay, from the lowest: compounds 1 and 3 (each within the scatter of the next); then compounds 2 and 4 (each within the scatter of the next).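

In this assay the exchange (a 1.1-fold higher number from compound 2 to compound 4 (0.03 log units; within the scatter)) shows that a change at this saturated chain carbon bound to a nitrogen on an aromatic ring can leave the number in place with the fluoro of compound 2, and not only in the dichloro pair of compound 1 and compound 3. The entering 1-(methylsulfonyl)piperidin-4-yl brings a sulfur and two oxygens and has one ring hetero atom where the leaving group has two, yet the read-out does not separate the two compounds. Nothing at hand explains why this exchange leaves the number where it was.

On these data alone, whether a carboxylic acid or a primary amine at this chain carbon would keep the number in the same range remains open. So does whether a plain piperidin-4-yl, without the methylsulfonyl, would read like compound 4.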